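Compound 3 to compound 4: trifluoromethyl in place of methyl

A few compounds are considered here, and "the series" means these few. Any claim that something is new, unique, unknown or untested is made for them only; others in the source may bear on it.

In an in vitro ADME assay on microsomes from liver (Homo sapiens) for metabolic stability, in the presence of a further agent that is not named here (a higher number here means faster removal of the compound, a lower number slower removal), compound 1 (`CC(C)(CO)CNC(=O)c1cc2cc(C#N)ccc2n1Cc1cccc(OC(F)(F)F)c1`) gives 20 mL.min-1.g-1 as a measured number. Compound 2 (`CC(C)(O)CCNC(=O)c1cc2cc(C#N)ccc2n1Cc1cccc(OC(F)(F)F)c1`) gives only a limit, < 6 mL.min-1.g-1 and no number. Compound 3 (`CC(O)CCNC(=O)c1cc2cc(C#N)ccc2n1Cc1cccc(OC(F)(F)F)c1`) is also a limit, < 6 mL.min-1.g-1 and no number. As far as these compounds go, compound 3 therefore stands on the limit of < 6 mL.min-1.g-1 in this assay, at which 2 of the 3 values shown sit, and its true value is unknown.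

Compound 4 (`N#Cc1ccc2c(c1)cc(C(=O)NCCC(O)C(F)(F)F)n2Cc1cccc(OC(F)(F)F)c1`) carries one change from compound 3 (trifluoromethyl in place of methyl on a saturated chain carbon bound to an oxygen on a saturated carbon and a saturated chain carbon). This is trifluoromethyl in place of methyl on a saturated chain carbon bound to an oxygen on a saturated carbon and a saturated chain carbon, so that 3-hydroxybutyl becomes 4,4,4-trifluoro-3-hydroxybutyl.

Going by the values given here, no measured step makes this change. The closest is a step that the two limits leave unreadable from compound 2 to compound 3 and it gives no size. The two readable steps, an at least 3.3-fold lower number from compound 1 to compound 2 (0.52 log units; beyond the scatter) and an at least 3.3-fold lower number from compound 1 to compound 3 (0.52 log units; beyond the scatter) and, both replace the 1-(hydroxymethyl)-1-methylethyl group, a different change, so they show only that the amide chain can shift the number in this assay at all. Neither size nor direction carries over, and no step beyond the scatter is expected.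

The expected step is a number no lower from compound 3 to compound 4 (the limit leaves the size open) with either direction open. For compound 4 the estimated intrinsic clearance is 6 mL.min-1.g-1 with an expected range from 3 mL.min-1.g-1 to 14 mL.min-1.g-1 and a report as a limit is about as likely as a number.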

Compound 4, intrinsic clearance in microsomes: 31 mL.min-1.g-1
The estimate for compound 4 lay 5.2-fold (0.71 log units) below the measured number; measured number outside the range, above it.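

In this assay, going by these compounds alone, the carbon bearing the hydroxyl of the 3-hydroxybutyl chain turns out to be sensitive to what it carries: trifluoromethyl in place of methyl there gives an at least 5.1-fold higher number from compound 3 to compound 4 (0.71 log units; beyond the scatter), whereas the only earlier step at this carbon, from compound 2 to compound 3, cannot be read. The 4,4,4-trifluoro-3-hydroxybutyl chain also separates compound 4 from the other tertiary-free and tertiary alcohol chains, with an at least 5.1-fold higher number from compound 2 to compound 4 (0.71 log units; beyond the scatter), while against the chain of compound 1 there is a 1.6-fold higher number from compound 1 to compound 4 (0.19 log units; within the scatter), so a change of this kind on the amide chain can undo the whole gain seen in the steps from compound 1 to compound 2 and compound 3. Both steps into compound 4 from the lower compounds give a minimum size only, with their true starting values unknown: the limit of < 6 mL.min-1.g-1 in this assay, at which 2 of the 4 values shown sit.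

As far as these compounds go, how much of the step belongs to the three fluorines, and whether an ethyl or a difluoromethyl group at this carbon would behave like methyl or like trifluoromethyl, stays open. Also open, from the compounds shown here alone, is whether trifluoromethyl on the 2-hydroxy-2-methylpropyl chain of compound 2 would give a step of the same direction.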